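The compounds below may be only part of what the source reports. "The series", "measured", "known", "first", "only" and "open" are said of these compounds alone.

Measured compounds:
- compound 1 `Cc1c(O)ccc2c1[C@H](Cn1cc(-c3ccc(F)cc3)nn1)[C@@]13CC(=O)[C@@](C)(CC[C@@H]21)C3` — > 20000 nM
- compound 2 `Cc1c(O)ccc2c1[C@H](Cn1cc(-c3ccccn3)nn1)[C@@]13CC(=O)[C@@](C)(CC[C@@H]21)C3` — > 20000 nM
- compound 3 `C=C1C[C@]23C[C@@]1(O)CC[C@H]2c1cc(Br)c(O)c(C)c1[C@@H]3Cn1cc(-c2ccc(F)cc2)nn1` — 6600 nM

In a functional assay on HL-60 cells (Homo sapiens) for cytotoxicity, read by MTT assay, with a stated time of 4 days (on this read-out lower numbers stand for stronger inhibition and higher numbers for weaker inhibition), compound 1 gives only a limit of the assay, > 20000 nM. In this assay compound 2 likewise gives only a limit, > 20000 nM. The change from compound 1 to compound 2 is pyridin-2-yl in place of 4-fluorophenyl on an aromatic carbon, and its size is a step that the two limits leave unreadable from compound 1 to compound 2; this follows from the limit of > 20000 nM in this assay, at which 2 of the 3 values shown sit. Among the measured compounds shown here, compound 3 is the one compound with a number, 6600 nM; how its core differs from that of compound 1 is not broken down here. Compound 4 `C=C1C[C@]23C[C@@]1(O)CC[C@H]2c1cc(Br)c(O)c(C)c1[C@@H]3Cn1cc(-c2ccccn2)nn1` has not been measured. It carries the same change as compound 2, (pyridin-2-yl in place of 4-fluorophenyl on an aromatic carbon), on the core of compound 3. No readable size for this change exists among the measured compounds, so the estimate for compound 4 rests on the value of compound 3, 6600 nM, with a wide margin. The expected step from compound 3 to compound 4 is a 1.2-fold higher number from compound 3 to compound 4 (0.08 log units; within the scatter). For compound 4 the estimated value in this assay is 8000 nM, expected between 2500 nM and 20000 nM.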

Compound 4, half-maximal inhibitory concentration: > 20000 nM
Compound 4 was reported as a limit (the forecaster's own chance of this, stated with the estimate: 30%); middle value at least 2.5-fold (0.39 log units) away from the limit.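

On the core of compound 3, pyridin-2-yl in place of 4-fluorophenyl gives in this assay an at least 3.0-fold higher number from compound 3 to compound 4 (0.48 log units; beyond the scatter) and thus a change beyond the scatter. Compound 4 gives only a limit of the assay (> 20000 nM), so the step has a floor and no full size: the limit of > 20000 nM in this assay, at which 3 of the 4 values shown sit. The same change between compound 1 and compound 2 cannot be read, and with one readable pair the compounds do not show that the step carries from one core to the other at the same size.

The compounds shown leave open what number compound 4 would give without the limit. They also leave open how an aminomethyl group or a carboxylic acid at this place would read in this assay on the core of compound 3.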